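The source may hold more compounds than are shown below. What is called first, only, known or untested is meant among the compounds shown, and "the series" means these compounds.

Working notes on the series in a functional assay (trachea) with Rattus norvegicus as the target; on this read-out higher numbers stand for higher potency (the scale is a negative logarithm) and lower numbers for lower potency. Compound 1 `CC1(C)C=C(n2ccccc2=O)c2cc(C(=O)c3ccco3)ccc2O1` gives 5.92; compound 2 `CC1(C)C=C(n2ccccc2=O)c2cc(C=O)ccc2O1` gives 6.14; compound 3 `CC1(C)C=C(n2ccccc2=O)c2cc(C(=N)S)ccc2O1` gives 5.96. On these three numbers compound 3 sits with the step of a number 0.04 log units higher from compound 1 to compound 3 (within the scatter) and the step of a number 0.18 log units lower from compound 2 to compound 3 (within the scatter), neither beyond the scatter. Compound 4 `CC1(C)C=C(n2ccccc2=O)c2cc(Br)ccc2O1` differs from compound 3 by one bromine atom in place of a group of 3 heavy atoms (1 carbon, 1 nitrogen, 1 sulfur; no ring), on an aromatic carbon. Going by the values given here, every measured step so far changed the same aromatic carbon: a number 0.22 log units higher from compound 1 to compound 2 (within the scatter), a number 0.04 log units higher from compound 1 to compound 3 (within the scatter) and a number 0.18 log units lower from compound 2 to compound 3 (within the scatter), all within the scatter. On that basis no step beyond the scatter is expected for compound 4 in this assay, the expected step being a number 0.04 log units higher from compound 3 to compound 4 (within the scatter). Compound 4 is therefore estimated at 6, with a range from 5.5 to 6.5.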

Compound 4, logarithm of the reciprocal of the active concentration, log(1/C): 7.53
Beside the measured number, compound 4's estimate is 1.53 log units below it; measured number above the stated range.
By their numbers in this assay, from the lowest: compounds 1, 3 and 2 (each within the scatter of the next); then compound 4.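

At this aromatic carbon the groups of compound 1, compound 2 and compound 3 stay within the scatter of one another, whereas bromo stands apart from all three in this assay with the steps of a number 1.57 log units higher from compound 3 to compound 4 (beyond the scatter) and a number 1.39 log units higher from compound 2 to compound 4 (beyond the scatter) and a number 1.61 log units higher from compound 1 to compound 4 (beyond the scatter) as its record. The position is thus sensitive to what it carries, and the flat picture held only among those three groups. Nothing at hand bears on why bromo differs. As far as these compounds go, whether the gain is particular to bromine or extends to chloro, methyl or nitrile at this carbon stays open, as does the outcome with an amine or plain hydrogen there.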